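This account rests on a few compounds, and the source may have more. Where it says the series, first, only, none or still open, it means among the compounds named here.

In a functional assay on HeLa cells (Homo sapiens) for inhibition, read by CCK-8 assay, with a stated time of 48 h (on this read-out lower numbers stand for stronger inhibition and higher numbers for weaker inhibition), compound 1 (`O=C(NCCNS(=O)(=O)c1sccc1-c1ccccc1Oc1ccc(O)c(O)c1)Nc1cc(C(F)(F)F)cc(C(F)(F)F)c1`) gives > 50000 nM, which is a limit of the assay and not a number. Compound 2 (`CC(C)c1ccc(Oc2ccc(O)c(O)c2)c(-c2ccsc2S(=O)(=O)NCCNC(=O)Nc2cc(C(F)(F)F)cc(C(F)(F)F)c2)c1`) gives > 50000 nM, which is also only a limit. Within the data shown here, the one measured step, a step that the two limits leave unreadable from compound 1 to compound 2, therefore has no readable size, and the whole record amounts to the limit of > 50000 nM in this assay, at which 2 of the 2 values shown sit. Compound 2 thus stands at the limit, with no measured number to anchor what follows. Compound 3 (`COc1ccc(Oc2ccc(C(C)C)cc2-c2ccsc2S(=O)(=O)NCCNC(=O)Nc2cc(C(F)(F)F)cc(C(F)(F)F)c2)cc1OC`) differs from compound 2 as follows: 3,4-dimethoxyphenyl in place of 3,4-dihydroxyphenyl on an oxygen on an aromatic ring. Among the measured compounds shown here, no measured step covers this exchange, since the only one concerns isopropyl in place of hydrogen. Neither a size nor a direction can be taken from the data, although a modest gain in inhibition remains possible. The expected step is an at least 1.2-fold lower number from compound 2 to compound 3 (0.09 log units; that floor lies within the scatter), and another limit would not be surprising. For compound 3, the estimated value is 40000 nM, with an expected range from 10000 nM to 100000 nM.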

Compound 3, half-maximal inhibitory concentration: 11600 nM
Estimate against measurement, compound 3: 3.4-fold (0.54 log units) above; measured number inside the range.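

In this assay, among these compounds, the exchange of 3,4-dihydroxyphenyl for 3,4-dimethoxyphenyl on an oxygen on an aromatic ring produces the first step with a readable lower bound: an at least 4.3-fold lower number from compound 2 to compound 3 (0.63 log units; beyond the scatter). Among the compounds shown here, this shows that the group at this position can move the read-out, which the earlier compounds could not show. The step can be stated only as a bound, and the change removes the 2 hydrogen-bond donors of the leaving group while adding carbon, so the result cannot assign the gain to either difference. Compound 3 alone gives a number, while the other compounds remain at a limit of the assay: the limit of > 50000 nM in this assay, at which 2 of the 3 values shown sit.

On these data alone, the step from compound 1 to compound 2 cannot be read, so the contribution of the isopropyl group stays open. Also open, as far as these compounds go, is whether a single methoxy group, or longer ethoxy groups, would give a lower number on this ring.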